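Ortho substituent swap on the benzoyl ring: methyl to bromo

The source may report more compounds than this note shows. Statements on the series, on what has been measured and on what is new or still open speak of the compounds shown alone.

Measured so far:
- compound 1, `COC(=O)c1c(C)[nH]c(C)c1C(=O)c1ccccc1Cl`, in a functional assay with Cavia porcellus as the target (a higher number here means that more compound is needed for the effect, a lower number that less compound is needed), gives 14000 nM
- compound 2, `COC(=O)c1c(C(=O)c2ccccc2Cc2ccccc2)c[nH]c1C`, in this assay gives 460 nM
- compound 3, `COC(=O)c1c(C)[nH]c(C)c1C(=O)c1ccccc1C`, in this assay gives 9470 nM

Compound 3 stands second highest of the three numbers in this assay. Its nearest neighbour is compound 1; the step of a 1.5-fold lower number from compound 1 to compound 3 (0.17 log units; within the scatter) is within the scatter, so the two cannot be ordered. Among the measured compounds shown here, compound 2, which carries a different substitution pattern on the shared core, sits far lower, a gap beyond the scatter, but no single-point step connects it to compound 3.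

Compound 4, `COC(=O)c1c(C)[nH]c(C)c1C(=O)c1ccccc1Br`, differs from compound 3 by bromo in place of methyl on an aromatic carbon. For the measured compounds named here, the only measured step that bears on this position is the one from compound 1 to compound 3, a chloro-to-methyl exchange at the same aromatic carbon, and it was within the scatter. Bromo is a second halogen at that place, so no step beyond the scatter is expected in this assay in either direction. Compound 4 is therefore expected to land near compound 3, with the step of a 1.3-fold higher number from compound 3 to compound 4 (0.10 log units; within the scatter) taken as noise around the compound 1 and compound 3 pair. The estimate for compound 4 in this assay is 12000 nM, with a range from 5000 nM to 30000 nM.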

Compound 4, half-maximal effective concentration: 8950 nM
Estimate against measurement, compound 4: 1.3-fold (0.13 log units) above; low and high end bracket the measured number.
By their numbers in this assay, from the lowest: compound 2; then compounds 4, 3 and 1 (each within the scatter of the next).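

In this assay, bromo in place of methyl on the aromatic carbon ortho to a large group gives (a 1.1-fold lower number from compound 3 to compound 4 (0.02 log units; within the scatter)), and bromo in place of chloro at the same carbon gives (a 1.6-fold lower number from compound 1 to compound 4 (0.19 log units; within the scatter)). Together with the earlier chloro-to-methyl exchange (a 1.5-fold lower number from compound 1 to compound 3 (0.17 log units; within the scatter)), these steps close the set of pairs among chloro, methyl and bromo, and all three pairs lie within the scatter, so these groups cannot be ordered at this position and exchanging one for another has no readable effect on the number. No measurement at hand bears on why these three groups cannot be told apart.

Compound 2, at 460 nM, differs from compounds 1, 3 and 4 in more than one place, so its steps to them cannot be read and the source of its much lower number remains unassigned. From the compounds shown here alone, it also remains open whether this aromatic carbon stays equally insensitive to a group of a different kind, such as an amine, a carboxylic acid or a longer chain, since the three groups compared here span only a narrow set of substituents.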